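The source may hold more compounds than are shown below. What is called first, only, known or untested is meant among the compounds shown, and "the series" means these compounds.

Compound 2 `COc1ccc(NC(=O)COC(=O)/C=C/c2cc(OC)c(OCc3ccc(Cl)c(Cl)c3)c(OC)c2)cc1` stands at the top of the numbers shown in a functional assay on HL-60 cells (Homo sapiens) for cytotoxicity, read by MTT assay, with a stated time of 72 h (a higher number here means a weaker inhibitor, a lower number a stronger inhibitor), where it gives > 200000 nM, which is a limit of the assay rather than a measured number. Compound 1 `COCOc1cc(/C=C/C(=O)OCC(=O)Nc2ccc(Cl)cc2)ccc1OCc1ccccc1` likewise returns only the limit > 200000 nM. Among the compounds with values here, compound 3 `COc1ccc(/C=C/C(=O)OCC(=O)Nc2ccc(Cl)cc2)cc1OC` is the one compound with a measured value, 31900 nM. Compound 4 `COc1ccc(NC(=O)COC(=O)/C=C/c2cc(OC)c(OCc3ccccc3)c(OC)c2)cc1` carries phenyl in place of 3,4-dichlorophenyl on a saturated chain carbon bound to an oxygen on an aromatic ring. Within the data shown here, no two measured compounds differ in a single place, so no measured step guides this change; what can be said is that compound 1, which also carries a benzyloxy group, sits at the limit of > 200000 nM in this assay, at which 2 of the 3 values shown sit. The step expected here, a number no higher from compound 2 to compound 4 (the limit leaves the size open), is none beyond the scatter. Compound 4 is expected at 200000 nM, with a range from 50000 nM to 400000 nM.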

Compound 4, half-maximal inhibitory concentration: > 200000 nM
Compound 4 gave a limit, no number; the forecaster's own chance of this, stated with the estimate: 60%; the middle value sits exactly at the limit.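

Compound 2 and compound 4 both return only a limit in this assay, so no step between them can be read: the limit of > 200000 nM in this assay, at which 3 of the 4 values shown sit.

The compounds shown leave open whether exchanging 3,4-dichlorobenzyl for benzyl changes cytotoxicity at all.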